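Benzyl-ether halogen swap on the acylurea series

The compounds below may be only part of what the source reports. "The series", "measured", "known", "first", "only" and "open" are said of these compounds alone.

Compound 3 `Cc1ccc(NC(=O)NC(=O)c2ccc(OCc3ccccc3F)cc2)cc1-c1nc2ccccc2[nH]1` stands as the most potent of the three measured compounds in a functional assay on MGC-803 cells (Homo sapiens) for inhibition, read by MTT assay, with a stated time of 48 h (a lower number here means a stronger inhibitor, a higher number a weaker inhibitor), giving 2520 nM; its nearest neighbour is compound 2 `Cc1ccc(NC(=O)NC(=O)c2ccc(OCc3ccc(C(F)(F)F)cc3)cc2)cc1-c1nc2ccccc2[nH]1` with 14900 nM, and the furthest is compound 1 `Cc1ccc(NC(=O)NC(=O)c2ccc(OCc3ccccc3)cc2)cc1-c1nc2ccccc2[nH]1` with 39400 nM. The measured steps were a 16-fold lower number from compound 1 to compound 3 (1.19 log units; beyond the scatter) and a 5.9-fold lower number from compound 2 to compound 3 (0.77 log units; beyond the scatter), while the trifluoromethyl step was a 2.6-fold lower number from compound 1 to compound 2 (0.42 log units; beyond the scatter).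

Compound 4 `Cc1ccc(NC(=O)NC(=O)c2ccc(OCc3cccc(Cl)c3Cl)cc2)cc1-c1nc2ccccc2[nH]1` differs from compound 3 by 2,3-dichlorophenyl in place of 2-fluorophenyl on a saturated chain carbon bound to an oxygen on an aromatic ring. Among the measured compounds shown here, no measured step exchanges one halogen for another, nor adds a second halogen to the ring that leaves; the measured steps bear on it only by showing that halogen on this ring moved the number downward in every case, most strongly for compound 3 with 2520 nM. A step within the scatter, or a modest move in either direction, is therefore expected for compound 4, and the estimated step of a 1.4-fold higher number from compound 3 to compound 4 (0.14 log units; within the scatter) reflects that. Compound 4 is estimated at 3500 nM, within 1000 nM to 12000 nM.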

Compound 4, half-maximal inhibitory concentration: > 100000 nM
Compound 4: a limit, no number; the forecaster's own chance of this, stated with the estimate: 3%; at least 28-fold (1.45 log units) between middle value and limit.
By their numbers in this assay, from the lowest: compound 3; then compound 2; then compound 1. At a limit, above all of these: compound 4.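

Compound 4 gives no number in this assay, only a limit of the assay: the limit of > 100000 nM in this assay, at which 1 of the 4 values shown sits. Halogen on this benzyl ring does not always lower the number: the 2,3-dichlorophenyl group gives an at least 39-fold higher number from compound 3 to compound 4 (1.59 log units; beyond the scatter), and it also gives an at least 6.7-fold higher number from compound 2 to compound 4 (0.82 log units; beyond the scatter) and an at least 2.5-fold higher number from compound 1 to compound 4 (0.40 log units; beyond the scatter). At this place on a saturated chain carbon bound to an oxygen on an aromatic ring, the number now moves in both directions with the ring's substituents: the downward move holds for compound 2 and compound 3, and compound 4 goes against it.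

The compounds shown do not separate chlorine itself from the presence of a second ring substituent as the source of this change, and a ring with one chlorine or with two fluorines would bear on that. As far as these compounds go, whether a methoxy or a nitrile on this ring stays near compound 3 also remains open.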